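The compounds below may be only part of what the source reports. "The series", "measured", "known", "first", "only" and "open" are said of these compounds alone.

Two pairs of compounds share one core and differ only in the group carried on an amide-type nitrogen. Compound 2 `O=C(CN1CCN(c2nnc(Cc3ccncc3)c3ccccc23)CC1)Nc1cccc(Br)c1` and compound 1 `Cc1ccc(NC(=O)CN2CCN(c3nnc(Cc4ccncc4)c4ccccc34)CC2)c(C)c1` were both tested in a functional assay on A549 cells (Homo sapiens) for cytotoxicity, read by MTT assay, with a stated time of 72 h; a higher number here means a weaker inhibitor, a lower number a stronger inhibitor. In this assay compound 2 gives 1530 nM, while compound 1 gives 45000 nM. The change between them is 2,4-dimethylphenyl in place of 3-bromophenyl on an amide-type nitrogen, and it produced a 29-fold higher number from compound 2 to compound 1 (1.47 log units; beyond the scatter). Compound 3 `O=C(CN1CCN(c2nnc(Cc3ccccc3)c3ccccc23)CC1)Nc1cccc(Br)c1` has a core that differs from the core of compound 2 by phenyl in place of pyridin-4-yl on a saturated chain carbon bound to an aromatic carbon; in this assay compound 3 gives "not active" (no number reported), and no number was given. Compound 4 `Cc1ccc(NC(=O)CN2CCN(c3nnc(Cc4ccccc4)c4ccccc34)CC2)c(C)c1` differs from compound 3 by 2,4-dimethylphenyl in place of 3-bromophenyl on an amide-type nitrogen; the place is the same word for word, so this is the same change as the one made between the two measured compounds. Since that change raised the number in a 29-fold higher number from compound 2 to compound 1 (1.47 log units; beyond the scatter) and compound 3 already shows no measurable activity, compound 4 is expected to remain without measurable activity and will most likely be reported only as a limit. Should a number be obtained, the estimate for compound 4 in this assay is 150000 nM, expected to fall between 40000 nM and 600000 nM.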

Compound 4, half-maximal inhibitory concentration: "not active" (no number reported)
Nothing numeric was reported for compound 4; the estimate stays without a comparison.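

In this assay compound 3 and compound 4 were both reported as not active, with no number, so no new step can be read between them. The compounds shown leave open how large the change from 3-bromophenyl to 2,4-dimethylphenyl is on the core of compound 3. No measurement shown here accounts for this result.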